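From Methyl to Amino on the Aryl Ring

The source may hold more compounds than are shown below. What is called first, only, known or untested is meant among the compounds shown, and "the series" means these compounds.

In a functional assay on MC-38 cells (Mus musculus) for antiproliferative activity, read by colorimetric assay and MTT assay (a lower number here means a stronger inhibitor, a higher number a weaker inhibitor), compound 2 (`Cc1ccc(S(=O)(=O)Nc2cccc3cc(Cl)[nH]c23)cc1`) gives 0.18 ug/mL. That value lies within the scatter of compound 3 (`N#Cc1ccc(S(=O)(=O)Nc2cccc3c(Cl)c[nH]c23)cc1`), which gives 0.13 ug/mL. Compound 1 (`O=S(=O)(Nc1cccc2cc[nH]c12)c1ccc(Cl)cc1`) gives 7 ug/mL, a number well beyond the scatter and higher than that of compound 2. Compound 4 (`Nc1ccc(S(=O)(=O)Nc2cccc3cc(Cl)[nH]c23)cc1`) departs from compound 2 in one place only, with amino in place of methyl on an aromatic carbon, para to a large group, so that 4-methylphenyl becomes 4-aminophenyl: amino in place of methyl on an aromatic carbon. Within the data shown here, no two measured compounds differ in just one place, so the data give no direct measure of what such an exchange does in this assay. The expectation therefore starts from compound 2 at 0.18 ug/mL and allows a small move toward a higher number. The expected step of a 1.4-fold higher number from compound 2 to compound 4 (0.14 log units; within the scatter) is not expected to exceed the scatter. For compound 4 the estimated value is 0.25 ug/mL, with an expected range from 0.07 ug/mL to 1 ug/mL.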

Compound 4, half-maximal inhibitory concentration: 2.9 ug/mL
The estimate for compound 4 lay 12-fold (1.06 log units) below the measured number; measured number above the stated range.
By their numbers in this assay, from the lowest: compounds 3 and 2 (each within the scatter of the next); then compound 4; then compound 1.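

Among these compounds, compound 4 and compound 2 give the only direct reading at this place on the aryl ring: in this assay, amino in place of methyl gives a 16-fold higher number from compound 2 to compound 4 (1.21 log units; beyond the scatter). The earlier compounds shown here differed from one another in more than one place, so they could not show that this position is so sensitive to a change of a single heavy atom, with carbon leaving, nitrogen entering and a hydrogen-bond donor and acceptor added. Nothing available bears on why the number moves this far.

From the compounds shown here alone, only methyl and amino can be compared at this place on this core, so it remains open how a hydroxyl, a methoxy or an acetamide would read there. Going by these compounds, it also remains open whether the exchange of methyl for amino would give a step of similar size on the core of compound 3.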